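From 4-fluorophenyl to ethoxycarbonyl in compound 2

The source may hold more compounds than are shown below. What is called first, only, known or untested is meant among the compounds shown, and "the series" means these compounds.

Of the compounds shown here, three sharing one core have been measured in a functional assay on HT-29 cells (Homo sapiens) for inhibition, read by MTT assay, with a stated time of 48 h (on this read-out higher numbers stand for weaker inhibition and lower numbers for stronger inhibition), so far. Compound 1 (`COc1ccc(-n2c(S)nnc2-c2cc(OC)c(OC)c(OC)c2)cc1`) returned only a limit, > 60000 nM, and no number. Compound 2 (`COc1ccc(-n2c(SCc3ccc(F)cc3)nnc2-c2cc(OC)c(OC)c(OC)c2)cc1`) gave 50700 nM, and compound 3 (`COc1ccc(-n2c(SCC(=O)c3ccc4ccccc4c3)nnc2-c2cc(OC)c(OC)c(OC)c2)cc1`) gave 53400 nM, two values within the scatter of each other. Among the measured compounds shown here, compound 2 therefore stands level with compound 3, the only other compound with a number.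

Compound 4 (`CCOC(=O)CSc1nnc(-c2cc(OC)c(OC)c(OC)c2)n1-c1ccc(OC)cc1`) has not yet been measured. Its difference from compound 2 is ethoxycarbonyl in place of 4-fluorophenyl on a saturated chain carbon bound to a sulfur.

For the measured compounds named here, two measured steps bear on this change. Placing 4-fluorobenzyl in place of hydrogen on a sulfur gave an at least 1.1-fold lower number from compound 1 to compound 2 (0.07 log units; that floor lies within the scatter), and the closer precedent, (naphthalen-2-yl)carbonyl in place of 4-fluorophenyl at the same place, gave a 1.1-fold higher number from compound 2 to compound 3 (0.02 log units; within the scatter). Neither step goes beyond the scatter, so no step beyond the scatter is expected in this assay for the new replacement. The estimated step is a 1.1-fold lower number from compound 2 to compound 4 (0.02 log units; within the scatter). For compound 4 the expected value is 48000 nM, with an estimated range from 25000 nM to 90000 nM.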

Compound 4, half-maximal inhibitory concentration: > 60000 nM
Compound 4 was reported as a limit; the forecaster's own chance of this, stated with the estimate: 35%; middle value at least 1.2-fold (0.09 log units) away from the limit.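

In this assay compound 4 gives > 60000 nM, which is a limit and not a number. The change gives an at least 1.1-fold higher number from compound 2 to compound 4 (0.07 log units; that floor lies within the scatter), and ethoxy in place of naphthalen-2-yl on a carbonyl carbon gives an at least 1.1-fold higher number from compound 3 to compound 4 (0.05 log units; that floor lies within the scatter); both are floors only, so neither shows a step beyond the scatter. What is new is that, among the groups on a saturated chain carbon bound to a sulfur, the ring-free ethoxycarbonyl is the one that returns no number, although the carbonyl-bearing chain of compound 3 does return one, and this places compound 4 with compound 1 at the same limit: the limit of > 60000 nM in this assay, at which 2 of the 4 values shown sit.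

On these data alone, the step joining compound 1 and compound 4 cannot be read, and the true size of the other two steps remains unknown. Also open, as far as these compounds go, is whether a carboxylic acid or an amide in place of ethoxycarbonyl, or a phenyl ring bearing no fluorine in place of 4-fluorophenyl, would return a number in this assay.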